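The source may hold more compounds than are shown below. What is called first, only, known or untested is meant among the compounds shown, and "the series" means these compounds.

Compound 2 `CON(C)C(=O)/C=C1\CCc2ccc(F)cc21` gives 17% in a functional assay on the whole organism with Mus musculus as the target, at a dose of 100 mg/kg by the intraperitoneal route (a higher number here means more inhibition at the dose given (going by the name of the read-out), a lower number less inhibition), the lowest of the two numbers in hand; compound 1 `CN(C)C(=O)/C=C1\CCc2ccc(F)cc21` gives 100%. Among the compounds with values here, the one measured step bears directly on this case: a number 83 percentage points lower from compound 1 to compound 2 (beyond the scatter). Within the data shown here, compound 3 `CCCNC(=O)/C=C1\CCc2ccc(F)cc21` differs from compound 2 by propylamino in place of methoxy(methyl)amino on a carbonyl carbon, which removes the methoxy again, though the propyl chain and the added hydrogen-bond donor have no measured counterpart. Because the methoxy cost a number 83 percentage points lower from compound 1 to compound 2 (beyond the scatter), a step back upward is expected, estimated as a number 53 percentage points higher from compound 2 to compound 3 (beyond the scatter). Compound 3 is therefore expected to give 70% in this assay, within 30% to 100%.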

Compound 3, a percentage reported as inhibition, in the whole organism at one dose (the size of the read-out at that dose, not a potency): 100%
Compound 3: the middle estimate sits 30 percentage points below what was measured; low and high end bracket the measured number.
By their numbers in this assay, from the lowest: compound 2; then compounds 1 and 3 (each within the scatter of the next).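

In this assay, propylamino in place of methoxy(methyl)amino on the carbonyl carbon gives a number 83 percentage points higher from compound 2 to compound 3 (beyond the scatter), so the low reading is specific to the methoxy(methyl)amino group and does not extend to every other group of that size at this place. Propylamino in place of dimethylamino gives no change at the digits printed from compound 1 to compound 3 (within the scatter), which shows that this place accepts a propyl chain and an amide hydrogen without a change in the reading at this dose. Nothing available explains why the methoxy(methyl)amino group stands apart.
Going by these compounds, whether the reading holds with a butyl or longer chain, or with a piperidine amide, remains open. On these data alone, compound 1 and compound 3 also stand level at this single dose, so how they compare at lower doses is unknown.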